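The source may report more compounds than this note shows. Statements on the series, on what has been measured and on what is new or still open speak of the compounds shown alone.

Measured in an ADME assay (liver) for metabolic stability, with Liver microsome (Rattus norvegicus) as the target, using microsomes and NADPH, with a stated time of 30 min, tested at 1 uM; on this read-out higher numbers stand for fast clearance and lower numbers for slow clearance:
Compound 1 `CS(=O)(=O)c1ccc(-c2cc(C(O)(C(F)(F)F)C(F)(F)F)cnc2N2CCN(S(=O)(=O)c3ccc(N)nc3)CC2)cc1` gives 103 mL.min-1.g-1
Compound 2 `Nc1ccc(S(=O)(=O)N2CCN(c3ncc(C(O)(C(F)(F)F)C(F)(F)F)cc3-c3cnccc3F)CC2)cn1` gives 22 mL.min-1.g-1
Compound 3 `Nc1ccc(S(=O)(=O)N2CCN(c3ncc(C(O)(C(F)(F)F)C(F)(F)F)cc3-c3cncc(F)c3)CC2)cn1` gives 19 mL.min-1.g-1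

Compound 3 cannot be told apart from compound 2, as the gap between them is small: a 1.2-fold lower number from compound 2 to compound 3 (0.06 log units; within the scatter). Both sit clearly under compound 1. The next compound, compound 4 `Nc1ccc(S(=O)(=O)N2CCN(c3ncc(C(O)(C(F)(F)F)C(F)(F)F)cc3-c3ccc4sccc4c3)CC2)cn1`, keeps the shared core and changes one group: 1-benzothiophen-5-yl in place of 5-fluoropyridin-3-yl on an aromatic carbon. Put simply, 1-benzothiophen-5-yl stands in place of 5-fluoropyridin-3-yl on an aromatic carbon.

Two measured steps made a swap at this same place, and both were modest but real: a 4.7-fold lower number from compound 1 to compound 2 (0.67 log units; beyond the scatter) and a 5.4-fold lower number from compound 1 to compound 3 (0.73 log units; beyond the scatter). In each, 4-(methylsulfonyl)phenyl gave way to a fluoropyridine. Compound 4 also gives up the fluoropyridine, for a group with no ring nitrogen, so a rise of similar size is expected. Going by the values given here, this is a loose analogy, since no measured compound carries 1-benzothiophen-5-yl. The expected step is a 4.5-fold higher number from compound 3 to compound 4 (0.65 log units; beyond the scatter). For compound 4 the estimated value is 85 mL.min-1.g-1, with an expected range from 30 mL.min-1.g-1 to 220 mL.min-1.g-1.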

Compound 4, intrinsic clearance in microsomes: 487 mL.min-1.g-1
Compound 4: the middle estimate sits 5.7-fold (0.76 log units) below what was measured; the measured number lies above the stated range.
By their numbers in this assay, from the lowest: compounds 3 and 2 (each within the scatter of the next); then compound 1; then compound 4.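

In this assay, going by these compounds alone, this position proves able to move clearance much further than the earlier compounds showed: 1-benzothiophen-5-yl gives a 26-fold higher number from compound 3 to compound 4 (1.41 log units; beyond the scatter) and a 22-fold higher number from compound 2 to compound 4 (1.35 log units; beyond the scatter), both large steps. It also exceeds the 4-(methylsulfonyl)phenyl group, with a 4.7-fold higher number from compound 1 to compound 4 (0.67 log units; beyond the scatter), so across these four compounds the two fluoropyridines give the low numbers, while the two groups without a ring nitrogen give clearly higher, though unequal, ones. No measured evidence on the cause of this rise is available here.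

The swap changes the ring nitrogen, the fluorine and the ring count all at once, so the compounds shown cannot separate their contributions. Where a plain phenyl or an unsubstituted pyridin-3-yl would fall at this position remains open.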